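Triazolylsulfanyl to methyltetrazolylsulfanyl on the shared core

The compounds below may be only part of what the source reports. "The series", "measured", "known", "first", "only" and "open" are said of these compounds alone.

Measured compounds:
- compound 1 `O=C(Nc1cc(Sc2ncn[nH]2)c(O)c2ccccc12)c1ccc(Cl)cc1`: 50.1%
- compound 2 `O=C(Nc1cc(Sc2ncn[nH]2)c(O)c2ccccc12)c1cccc([N+](=O)[O-])c1`: 29.3%

In an assay on isolated protein for inhibition of RAC-alpha serine/threonine-protein kinase (Homo sapiens), read by fluorescence, with a stated time of 30 min, tested at 10 uM (on this read-out higher numbers stand for more inhibition at the one concentration tested (going by the name of the read-out) and lower numbers for less inhibition), compound 1 gives 50.1% and stands highest of the two numbers; the nearest is compound 2, which gives 29.3%. For the measured compounds named here, the one measured step, a number 20.8 percentage points lower from compound 1 to compound 2 (beyond the scatter), concerns the group on the carbonyl carbon only.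

Compound 3 `Cn1nnnc1Sc1cc(NC(=O)c2ccc(Cl)cc2)c2ccccc2c1O` is not yet measured. It differs from compound 1 at another place: 1-methyl-1H-tetrazol-5-yl in place of 1H-1,2,4-triazol-5-yl on a sulfur. Going by the values given here, no measured step touches the group on the sulfur, so nothing speaks to the size or direction of this change. The expectation for compound 3 therefore rests on compound 1 alone, with a step of a number 5.1 percentage points lower from compound 1 to compound 3 (within the scatter) expected to stay within the scatter, and a wide range. Compound 3 is estimated at 45% in this assay, between 20% and 70%.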

Compound 3, a percentage reported as inhibition, at one concentration (the size of the read-out at that concentration, not a potency): 13.1%
Estimate against measurement, compound 3: 31.9 percentage points above, and the stated range ends above it.
By their numbers in this assay, from the lowest: compound 3; then compound 2; then compound 1.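

In this assay the group on the sulfur proves to be a sensitive place on the shared core, with a number 37 percentage points lower from compound 1 to compound 3 (beyond the scatter); this step is large, whereas the earlier change on the carbonyl carbon was modest. The exchange alters several things at once: the ring gains a fourth hetero atom, a methyl group enters, and the count of hydrogen-bond donors on the group goes from 1 to 0, so this single step cannot assign the drop to any one of them. No supporting data bear on why the number falls.

Still open, from the compounds shown here alone, is which part of the exchange matters, a question that 1H-tetrazol-5-yl or 1-methyl-1H-1,2,4-triazol-5-yl on the sulfur would address. Also open, going by these compounds, is how a simple amine or a carboxylic acid in that place would read.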